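Ring-Closed Amidine Swap and the Expected Value for Compound 4

This account rests on a few compounds, and the source may have more. Where it says the series, first, only, none or still open, it means among the compounds named here.

Compound 1 `CC(C)NC(=N)c1ccc2oc(-c3cccc(OCCCCOc4ccccc4)c3)cc2c1`: in an ADME assay on L6 cells (Rattus norvegicus) for cytotoxicity, read by resazurin assay, with a stated time of 70 h (on this read-out lower numbers stand for stronger inhibition and higher numbers for weaker inhibition), compound 1 gives 36500 nM.
Compound 2 `c1ccc(OCCCCOc2cccc(-c3cc4cc(C5=NCCN5)ccc4o3)c2)cc1`: in this assay compound 2 gives 9500 nM.
Compound 3 `CC(C)NC(=N)c1ccc2cc(-c3cccc(OCCCOc4ccccc4)c3)oc2c1`: in this assay compound 3 gives 82300 nM.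

Compound 4 `c1ccc(OCCCOc2cccc(-c3cc4ccc(C5=NCCN5)cc4o3)c2)cc1` has not been measured yet. The change from compound 1 to compound 2 is a group of 5 heavy atoms (3 carbon, 2 nitrogen; one five-membered non-aromatic ring with 2 hetero atoms) in place of a group of 6 heavy atoms (4 carbon, 2 nitrogen; no ring), on an aromatic carbon, and in this assay it produced a 3.8-fold lower number from compound 1 to compound 2 (0.58 log units; beyond the scatter). The change from compound 3 to compound 4 is a group of 5 heavy atoms (3 carbon, 2 nitrogen; one five-membered non-aromatic ring with 2 hetero atoms) in place of a group of 6 heavy atoms (4 carbon, 2 nitrogen; no ring), on an aromatic carbon, the same change at a place described in identical words. How the core of compound 3 differs from the core of compound 1 is not broken down here. Compound 3 stands highest of the three measured numbers. Among the compounds with values here, a step of similar size is expected because a 3.8-fold lower number from compound 1 to compound 2 (0.58 log units; beyond the scatter) is the only precedent, giving an estimated 3.7-fold lower number from compound 3 to compound 4 (0.57 log units; beyond the scatter). Compound 4 is therefore expected to show about 22000 nM in this assay, plausibly between 9000 nM and 50000 nM.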

Compound 4, half-maximal inhibitory concentration: 10100 nM
Beside the measured number, compound 4's estimate is 2.2-fold (0.34 log units) above it; measured number inside the range.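

In this assay, putting the five-membered non-aromatic ring group in place of the open-chain group on the aromatic carbon gives an 8.1-fold lower number from compound 3 to compound 4 (0.91 log units; beyond the scatter), the same direction as the earlier step, and the two steps cannot be told apart in size: the same change on two cores in this assay, a 3.8-fold lower number (0.58 log units; beyond the scatter) from compound 1 to compound 2 and an 8.1-fold lower number (0.91 log units; beyond the scatter) from compound 3 to compound 4, 2.1-fold (0.33 log units) apart, within the scatter of two such steps. The change therefore carries over between these two cores, with a similar lowering of the number on each. This does not show that it would hold on any further core, and two pairs cannot explain why the number falls.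

The compounds shown leave open whether a plain amine or a carboxylic acid at the same aromatic carbon would lower the number too. They also leave open how a longer chain on the open-chain group would compare.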